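Sulfur to Selenium on a Shared Core

The compounds below may be only part of what the source reports. "The series", "measured", "known", "first", "only" and "open" are said of these compounds alone.

Measured so far:
compound 1, `O=C(/N=C(/NC(=O)c1cc(-c2ccccc2)nc2ccccc12)[Se]Cc1ccccc1)c1cc(-c2ccccc2)nc2ccccc12` — > 100000 nM in a functional assay on HT-29 cells (Homo sapiens) for cytotoxicity, read by MTT assay, with a stated time of 72 h; on this read-out lower numbers stand for stronger inhibition of growth and higher numbers for weaker inhibition of growth
compound 2, `CS/C(=N\C(=O)c1cc(-c2ccccc2)nc2ccccc12)NC(=O)c1cc(-c2ccccc2)nc2ccccc12` — > 100000 nM in this assay

Compound 1 gave > 100000 nM in this assay, which is a limit of the assay rather than a measured number. Compound 2 gave > 100000 nM in this assay, again only a limit. Compound 2 therefore stands only at a limit on the numbers shown, and the same holds for the one other measured compound. Among the compounds with values here, the single measured step, a step that the two limits leave unreadable from compound 1 to compound 2, cannot be sized, since the limit of > 100000 nM in this assay, at which 2 of the 2 values shown sit, covers both of its ends. Compound 3, `C[Se]/C(=N\C(=O)c1cc(-c2ccccc2)nc2ccccc12)NC(=O)c1cc(-c2ccccc2)nc2ccccc12`, is reached from compound 2 by a group of 2 heavy atoms (1 carbon, 1 selenium; no ring) in place of a group of 2 heavy atoms (1 carbon, 1 sulfur; no ring), on a carbon with a double bond to nitrogen. Within the data shown here, no measured step bears on this particular change: the only comparison available swaps a larger group for a smaller one and yields no number. The expectation for compound 3 can thus rest only on the fact that both measured relatives reported a limit; the estimated step that the limit leaves unreadable from compound 2 to compound 3 is taken as none beyond the scatter. Compound 3 is therefore expected to give about 150000 nM in this assay, within 50000 nM to 500000 nM, most probably again as a limit.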

Compound 3, concentration for total growth inhibition: 90700 nM
The estimate for compound 3 lay 1.7-fold (0.22 log units) above the measured number; the measured number falls inside the stated range.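

Within the data shown here, compound 3, which carries a methyl group on selenium where compound 2 has methylsulfanyl, is the only one of the three compounds to give a real number rather than a limit in this assay. Exchanging sulfur for selenium at this carbon with a double bond to nitrogen gives an at least 1.1-fold lower number from compound 2 to compound 3 (0.04 log units; that floor lies within the scatter), and hydrogen in place of phenyl on the saturated chain carbon bound to a selenium atom gives an at least 1.1-fold lower number from compound 1 to compound 3 (0.04 log units; that floor lies within the scatter). Both steps are floors and not sizes, so neither one shows a change beyond the scatter, and the true gaps could be larger or could be too small to matter, with the far end of each step resting on a limit: the limit of > 100000 nM in this assay, at which 2 of the 3 values shown sit.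

Going by these compounds, the real difference between the sulfur and selenium compounds stays open, as does whether any growth inhibition depends on selenium at all. Also open, on these data alone, is how the number would respond to a different group on selenium at this carbon, such as an ethyl or a longer chain, or to an amine there in place of the selenium group.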